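A few compounds are considered here, and "the series" means these few. Any claim that something is new, unique, unknown or untested is made for them only; others in the source may bear on it.

Two compounds built on a shared core have so far been examined in an assay on membranes from CHO cells for displacement of a labelled ligand from adenosine receptor A1 (Homo sapiens), read by scintillation counting, with a stated time of 60 min, tested at 1 uM; a lower number here means less inhibition, a higher number more inhibition at the concentration tested (going by the name of the read-out). Compound 1 `CC1=C(C(=O)OC(C)(C)C)C(c2ccoc2)NC(=O)N1` gives 11% in this assay. Compound 2 `COC(=O)C1=C(C)NC(=S)NC1c1ccoc1` gives 25%, the higher of the two numbers, and its gap from compound 1 lies beyond the usual scatter. Compound 3 `CC1=C(C(=O)OCC(C)C)C(c2ccoc2)NC(=S)N1` has not yet been measured in this assay. It differs from compound 2 in one place: isopropyl in place of hydrogen on a saturated chain carbon bound to an oxygen next to a carbonyl group. Among the compounds with values here, no measured pair shows this change on its own, so its effect is unknown; compound 1 and compound 2 differ in more than one place and offer no guide to it. The step of a number 3 percentage points lower from compound 2 to compound 3 (within the scatter) is expected to stay within the usual scatter, with no clear direction. In this assay compound 3 is estimated at 22%, with a range from 5% to 40%.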

Compound 3, a percentage reported as inhibition, at one concentration (the size of the read-out at that concentration, not a potency): 12%
Compound 3: the middle estimate sits 10 percentage points above what was measured, and the stated range covers the measured number.
By their numbers in this assay, from the lowest: compounds 1 and 3 (each within the scatter of the next); then compound 2.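

With the step in hand, isopropyl in place of hydrogen on a saturated chain carbon bound to an oxygen next to a carbonyl group, which also reads as methoxy to isobutoxy, now has a measured effect in this assay, giving a number 13 percentage points lower from compound 2 to compound 3 (beyond the scatter). This position therefore does not accept the change without consequence, and here the larger group goes with less inhibition at the concentration tested. Nothing available explains the step.

Within the data shown here, this single pair is the only guide to the position, so it cannot show whether the number falls gradually as the chain grows or whether the branching of the isobutoxy group matters. Ethoxy, a straight butoxy chain or a chain ending in an amine at this place would be needed to separate these possibilities.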